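This account rests on a few compounds, and the source may have more. Where it says the series, first, only, none or still open, it means among the compounds named here.

Measured compounds:
compound 1, `O=C(Nc1ccc(-c2nn[nH]n2)cc1)c1cccc(-c2nn[nH]n2)c1` — 0.6 mg/kg
compound 2, `O=C(O)c1cc(NC(=O)c2ccc([N+](=O)[O-])cc2)cc(C(=O)O)c1` — 61.1 mg/kg
compound 3, `NC(=O)c1ccc(NC(=O)c2ccc(-c3nn[nH]n3)cc2)cc1` — 33 mg/kg

In a functional assay on the whole organism (stomach) with Rattus norvegicus as the target (a higher number here means that more compound is needed for the effect, a lower number that less compound is needed), compound 2 gives the highest number of the three. Its nearest neighbour is compound 3, whose value lies within the scatter of that of compound 2; compound 1 lies well beyond it, with a far lower number. Within the data shown here, no pair of these differs in a single place, so no measured step exists from which to read the effect of a single change.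

Compound 4, `O=C(O)c1cc(NC(=O)c2ccc(Cl)cc2)cc(C(=O)O)c1`, differs from compound 2 as follows: chloro in place of nitro on an aromatic carbon

Among the measured compounds shown here, no measured step of this kind is available here. Exchanging one group for another on the same aromatic carbon is expected to move the value little, if at all, beyond the scatter, in no firm direction. Compound 4 is therefore estimated at 50 mg/kg, with a range from 15 mg/kg to 150 mg/kg. This estimate means an expected step of a 1.2-fold lower number from compound 2 to compound 4 (0.09 log units; within the scatter), within the scatter.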

Compound 4, dose for 50% inhibition: 97.3 mg/kg
Estimate against measurement, compound 4: 1.9-fold (0.29 log units) below; the measured number falls inside the stated range.
By their numbers in this assay, from the lowest: compound 1; then compounds 3, 2 and 4 (each within the scatter of the next, the first and the last beyond it).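

Chloro in place of nitro on the aromatic carbon para to a large group gives a 1.6-fold higher number from compound 2 to compound 4 (0.20 log units; within the scatter) in this assay. Among these compounds, this is the first single-place step, and at this position the exchange of three heavy atoms for one leaves the number within the scatter. Nothing measured here explains this result.

As far as these compounds go, whether an amine or a methoxy group on this carbon would also stay within the scatter remains open. Among the compounds shown here, no single-place step links compound 1 to compound 2 or compound 4, so the change behind its far lower number cannot be identified.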